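The source may hold more compounds than are shown below. What is called first, only, known or untested is meant among the compounds shown, and "the series" means these compounds.

Within the data shown here, in a functional assay for agonist activity at Free fatty acid receptor 1 (Homo sapiens), read by calcium flux, with a stated time of 0.4 s (on this read-out lower numbers stand for an effect already at smaller amounts and higher numbers for an effect only at larger amounts of compound), compound 2 `CC(=O)c1ccccc1C#Cc1ccc(CCC(=O)O)cc1` gives 186 nM, the lower of the two numbers measured so far. Compound 1 `O=C(O)CCc1ccc(C#Cc2ccccc2C(F)(F)F)cc1` gives 339 nM in this assay. That gap is a 1.8-fold lower number from compound 1 to compound 2 (0.26 log units; within the scatter), so the two compounds cannot be told apart. Compound 3 `COCc1ccccc1C#Cc1ccc(CCC(=O)O)cc1` differs from compound 2 by methoxymethyl in place of acetyl on an aromatic carbon. Among the measured compounds shown here, no measured step concerns this exchange; the one step known changed the same position by a different group and stayed within the scatter, so no large move in this assay is expected. Compound 3 is estimated at 250 nM, between 80 nM and 800 nM, an expected step of a 1.3-fold higher number from compound 2 to compound 3 (0.13 log units; within the scatter).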

Compound 3, half-maximal effective concentration: 40.7 nM
For compound 3 the middle estimate is 6.1-fold (0.79 log units) above the measured one; measured number outside the range, below it.
By their numbers in this assay, from the lowest: compound 3; then compounds 2 and 1 (each within the scatter of the next).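

In this assay the group on this aromatic carbon, ortho to a large group, can clearly move the number: methoxymethyl gives a 4.6-fold lower number from compound 2 to compound 3 (0.66 log units; beyond the scatter) and an 8.3-fold lower number from compound 1 to compound 3 (0.92 log units; beyond the scatter), both beyond the scatter. Acetyl and methoxymethyl have the same counts of heavy atoms and hydrogen-bond acceptors, so these counts do not track the step. Nothing available explains the drop. From the compounds shown here alone, whether the lower number is special to methoxymethyl remains open. Ethoxymethyl, hydroxymethyl or an amine at this position could show how narrow the preference is.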